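The source may report more compounds than this note shows. Statements on the series, on what has been measured and on what is new or still open speak of the compounds shown alone.

Going by the values given here, in an ADME assay on microsomes from liver (Homo sapiens) for metabolic stability, read by LC-MS (on this read-out higher numbers stand for a longer-lived compound and lower numbers for a shorter-lived compound), two compounds built on the same core have numbers so far. Compound 1 `COc1ccc(-c2ccc3ncc(-c4nnco4)c(NCCCn4ccnc4)c3c2)cc1` gives 0.166 h, and compound 2 `Nc1ccc(-c2ccc3ncc(-c4nnco4)c(NCCCn4ccnc4)c3c2)cc1` gives 1.15 h, the higher of the two. Compound 3 `Cc1ccc(-c2ccc3ncc(-c4nnco4)c(NCCCn4ccnc4)c3c2)cc1` has not been measured yet. It differs from compound 2 by one group: methyl in place of amino on an aromatic carbon. In words, this is methyl in place of amino on an aromatic carbon, para to a large group.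

Among the compounds with values here, only one measured step bears on this change, and it involves the same amino group: a 6.9-fold higher number from compound 1 to compound 2 (0.84 log units; beyond the scatter). That step is modest but beyond the scatter, and in it the amino compound has the higher number. Within the data shown here, no compound with a methyl group has been measured, so this single comparison is thin evidence, and methyl need not behave like methoxy. Losing the amino group is still expected to lower the number, by somewhat less than the measured step. The expected step is a 3.3-fold lower number from compound 2 to compound 3 (0.52 log units; beyond the scatter). For compound 3 the estimated half-life is 0.35 h, with an expected range from 0.12 h to 1 h.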

Compound 3, half-life in the Homo sapiens assay: 0.13 h
For compound 3 the middle estimate is 2.7-fold (0.43 log units) above the measured one; measured number inside the range.
By their numbers in the Homo sapiens assay, from the lowest: compounds 3 and 1 (each within the scatter of the next); then compound 2.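

Methyl in place of amino gives an 8.8-fold lower number from compound 2 to compound 3 (0.95 log units; beyond the scatter) in the Homo sapiens assay, and methyl in place of methoxy gives a 1.3-fold lower number from compound 1 to compound 3 (0.11 log units; within the scatter), so compound 1 and compound 3 cannot be told apart in this assay. Among these three compounds, then, the longer half-life goes with the amino group alone at this position on the aromatic ring, whereas methyl and methoxy give numbers within the scatter of each other. In a physicochemical assay for solubility (a higher number here means a more soluble compound, a lower number a less soluble compound), compound 2 gives 30.2 ug/mL and compound 3 gives 0.3 ug/mL. The same swap from amino to methyl also matters for how much compound dissolves in the physicochemical assay, and there the effect is larger than in the half-life: the measured solubility of compound 2, 30.2 ug/mL, and of compound 3, 0.3 ug/mL, a 100-fold lower number (2.00 log units; beyond the scatter)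

Still open, going by these compounds, is whether the longer half-life belongs to the amino group itself or would also appear with a hydroxyl group, a methylamino group or an acetamide on this aromatic carbon. Three compounds also cannot show why the half-life shifts, whether the half-life and solubility results share a single cause, or whether the same step would hold on a different core.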